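This account rests on a few compounds, and the source may have more. Where it says the series, first, only, none or still open, it means among the compounds named here.

Working notes on the series in a physicochemical assay for solubility, at pH 7.4; a lower number here means a less soluble compound, a higher number a more soluble compound.

Compound 1 `CC(=O)N1CCc2cc(-c3cccc4c3CCCC4)cc(N3CCCC3=O)c21` gives 271000 nM in this assay. Compound 2 `CC(=O)N1CCc2cc(-c3cccc4c3CCCC4)cc(N3CCCCC3=O)c21` gives 259000 nM in this assay. The two differ by 2-oxopiperidin-1-yl in place of 2-oxopyrrolidin-1-yl on an aromatic carbon, and that change produced a 1.0-fold lower number from compound 1 to compound 2 (0.02 log units; within the scatter).

Compound 3 `O=C([C@@H]1C[C@H]1c1cccc(N2CCCC2=O)c1)N1CCN(C2CCC2)CC1` is built on another core; the difference between the two cores is not broken down here. In this assay compound 3 reports only a limit of the assay, > 4130000 nM, and no number.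

Compound 4 `O=C([C@@H]1C[C@H]1c1cccc(N2CCCCC2=O)c1)N1CCN(C2CCC2)CC1` has not yet been measured in this assay. It differs from compound 3 by 2-oxopiperidin-1-yl in place of 2-oxopyrrolidin-1-yl on an aromatic carbon. For the measured compounds named here, this is the same kind of change as the one measured between compound 1 and compound 2, but the surroundings are not identical: in compound 1 the aromatic carbon is part of a fused or bridged system of two rings, ortho to a fused ring and meta to a fused ring as well as meta to a large group, whereas in compound 3 it is meta to a large group only.

Going by the values given here, compound 4 is expected to show a number no higher from compound 3 to compound 4 (the limit leaves the size open), set beside the measured 1.0-fold lower number from compound 1 to compound 2 (0.02 log units; within the scatter), which is the only measured instance of this change. Given the limit of > 4130000 nM in this assay, at which 1 of the 3 values shown sits, for compound 3, compound 4 is estimated at 4130000 nM, with an expected range from 2000000 nM to 8000000 nM, and is likely to be reported again only as a limit.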

Compound 4, solubility: > 3000000 nM
Compound 4 ended at the assay's limit; the forecaster's own chance of this, stated with the estimate: 75%; the middle value does not contradict the limit.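

Compound 3 gives > 4130000 nM in this assay and this is a limit of the assay, not a number. Compound 4 gives > 3000000 nM in this assay and this too is only a limit. The step from compound 3 to compound 4 therefore cannot be read. The compounds shown leave open whether 2-oxopiperidin-1-yl in place of 2-oxopyrrolidin-1-yl shifts the read-out on the core of compound 3, and by how much.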